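Adding an Amino Group to a Phenyl-Bearing Core

The source may hold more compounds than are shown below. What is called first, only, known or untested is meant among the compounds shown, and "the series" means these compounds.

Compound 1 `Cc1ccc(-c2c3ccc4ccccc4c3nc3c2c(C)nc2c4ccccc4ccc32)cc1` gives 67000 nM in a functional assay on HCT-116 cells (Homo sapiens) for cytotoxicity, read by MTT assay, with a stated time of 48 h; on this read-out lower numbers stand for stronger inhibition and higher numbers for weaker inhibition.
Compound 2 `Cc1nc2c3ccccc3ccc2c2nc3c(ccc4ccccc43)c(-c3cc([N+](=O)[O-])ccc3N)c12` gives 6010 nM in this assay.
Compound 3 `Cc1nc2c3ccccc3ccc2c2nc3c(ccc4ccccc43)c(-c3ccccc3)c12` gives only a limit, > 80000 nM, in this assay.

Compound 3 thus sits at the top of the measured range, at the limit of > 80000 nM in this assay, at which 1 of the 3 values shown sits, where no number is returned. Compound 4 `Cc1nc2c3ccccc3ccc2c2nc3c(ccc4ccccc43)c(-c3ccccc3N)c12` differs from compound 3 by amino in place of hydrogen on an aromatic carbon. The closest measured step runs the other way: an at least 13-fold higher number from compound 2 to compound 3 (1.12 log units; beyond the scatter), and an 11-fold lower number from compound 1 to compound 2 (1.05 log units; beyond the scatter) points the same way. Because compound 2 gives 6010 nM with the full 2-amino-5-nitrophenyl group while compound 4 carries only its amino part, a number above that of compound 2 yet below where compound 3 stands is expected. Compound 4 is therefore expected to give 25000 nM, between 6000 nM and 80000 nM. That estimate means an expected step of an at least 3.2-fold lower number from compound 3 to compound 4 (0.50 log units; beyond the scatter).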

Compound 4, half-maximal inhibitory concentration: 4760 nM
Estimate against measurement, compound 4: 5.3-fold (0.72 log units) above; the measured number lies below the stated range.
By their numbers in this assay, from the lowest: compounds 4 and 2 (each within the scatter of the next); then compound 1. At a limit, above all of these: compound 3.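

Amino in place of hydrogen on this aromatic carbon, ortho to a large group, is enough on its own for a large change, with an at least 16-fold lower number from compound 3 to compound 4 (1.22 log units; beyond the scatter). Removing the nitro group changes nothing that can be read, with a 1.3-fold lower number from compound 2 to compound 4 (0.10 log units; within the scatter), so the amino group alone matches the full 2-amino-5-nitrophenyl group. The 2-aminophenyl group also clearly beats 4-methylphenyl, with a 14-fold lower number from compound 1 to compound 4 (1.15 log units; beyond the scatter).

On these data alone, the true size of the first step stays open, as compound 3 gives only a limit: the limit of > 80000 nM in this assay, at which 1 of the 4 values shown sits. As far as these compounds go, whether a hydroxyl or a methylamino group on that carbon would serve as well also remains open.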